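The source may hold more compounds than are shown below. What is called first, only, known or untested is meant among the compounds shown, and "the series" means these compounds.

Measured in a functional assay on MDA-MB-231 cells (Homo sapiens) for antiproliferative activity, read by MTT assay, with a stated time of 48 h; on this read-out higher numbers stand for weaker inhibition and lower numbers for stronger inhibition:

- Compound 1 `COc1ccccc1-n1cc(COC(=O)/C(C)=C/CC/C(C)=C/CC/C(C)=C/CC[C@@H]2[C@@]3(C)CCC(=O)C(C)(C)[C@H]3CC[C@@]2(C)O)nn1`: > 150000 nM, a limit of the assay
- Compound 2 `C/C(=C\CC/C(C)=C/CC[C@@H]1[C@@]2(C)CCC(=O)C(C)(C)[C@H]2CC[C@@]1(C)O)CC/C=C(\C)C(=O)OCc1cn(-c2ccccc2)nn1`: > 150000 nM, a limit of the assay

Compound 2 has only a limit and no number, so its place in the series cannot be ranked. The same holds for compound 1, and the whole data set amounts to the limit of > 150000 nM in this assay, at which 2 of the 2 values shown sit.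

Compound 3 `C/C(=C\CC/C(C)=C/CC[C@@H]1[C@@]2(C)CCC(=O)C(C)(C)[C@H]2CC[C@@]1(C)O)CC/C=C(\C)C(=O)OCc1cn(-c2cccc(O)c2)nn1` differs from compound 2 by one change, (hydroxy in place of hydrogen on an aromatic carbon). This is hydroxy in place of hydrogen on an aromatic carbon, taking phenyl to 3-hydroxyphenyl.

For the measured compounds named here, the only measured step bearing on this is a step that the two limits leave unreadable from compound 1 to compound 2. It concerns a different group, hydrogen in place of methoxy on an aromatic carbon, on the same aromatic ring, and it gives no size. The data therefore offer no measured basis for a sized step in this assay in either direction, and no step beyond the scatter is expected. A reading that again returns only a limit is the likeliest outcome.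

The estimated step is a number no higher from compound 2 to compound 3 (the limit leaves the size open).

Compound 3 is expected near 150000 nM, with an estimated range of 50000 nM to 300000 nM.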

Compound 3, half-maximal inhibitory concentration: 139000 nM
Beside the measured number, compound 3's estimate is 1.1-fold (0.03 log units) above it, and the stated range covers the measured number.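

In this assay, for the compounds shown here, compound 3 gives 139000 nM, the first actual number, obtained with hydroxy on an aromatic carbon of the six-membered aromatic ring, meta to a large group. Compound 1 and compound 2 remain limits of the assay, not numbers: the limit of > 150000 nM in this assay, at which 2 of the 3 values shown sit. Hydroxy in place of hydrogen gives an at least 1.0-fold lower number from compound 2 to compound 3 (0.03 log units; that floor lies within the scatter), and 3-hydroxyphenyl in place of 2-methoxyphenyl gives an at least 1.0-fold lower number from compound 1 to compound 3 (0.03 log units; that floor lies within the scatter), so this position can carry a change that yields a readable value, but neither step establishes a gain beyond the scatter.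

On these data alone, the true size of both steps stays open, as the values for compound 1 and compound 2 fix them from one side only, and a single readable value shows no trend at this position. Also open, as far as these compounds go, are how an amine or a carboxylic acid in place of hydroxy on the same ring would read, and whether hydroxy on another carbon of that ring would give a number in this assay.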